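Moving the hydroxy group on the shared core: compound 3 to compound 4

The compounds below may be only part of what the source reports. "The series", "measured", "known", "first", "only" and "open" are said of these compounds alone.

Measured in a functional assay on U-937 cells (Homo sapiens) for cytotoxicity, read by MTT assay, with a stated time of 48 h; a lower number here means a stronger inhibitor, a higher number a weaker inhibitor:
compound 1 `Fc1cccc(-c2nc(Nc3ccccc3)c3cc(F)ccc3n2)c1` gives 45500 nM.
compound 2 `Fc1cccc(-c2nc(Nc3ccccc3Br)c3cc(F)ccc3n2)c1` gives > 50000 nM, which is a limit of the assay and not a number.
compound 3 `Oc1ccc(Nc2nc(-c3cccc(F)c3)nc3ccc(F)cc23)cc1` gives > 50000 nM, likewise a limit of the assay.

Compound 3 thus stands at the edge of what this assay reports: its value is a limit, and it shares that position with one other compound, as the limit of > 50000 nM in this assay, at which 2 of the 3 values shown sit, records. Compound 4 `Oc1cccc(Nc2nc(-c3cccc(F)c3)nc3ccc(F)cc23)c1` differs from it only in where the hydroxy group sits on the ring attached to the nitrogen: 3-hydroxyphenyl in place of 4-hydroxyphenyl on a nitrogen on an aromatic ring. Among the compounds with values here, two measured steps bear on this change, both starting from the unsubstituted phenyl ring of compound 1: an at least 1.0-fold higher number from compound 1 to compound 2 (0.04 log units; that floor lies within the scatter), and an at least 1.0-fold higher number from compound 1 to compound 3 (0.04 log units; that floor lies within the scatter). In each case adding a group to that ring pushed the value to the limit, with the floor of each step lying within the scatter. The remaining comparison is a step that the two limits leave unreadable from compound 2 to compound 3. Nothing in these steps points to a gain from a hydroxy group on this ring. Compound 4 is therefore expected to show a step of a number no higher from compound 3 to compound 4 (the limit leaves the size open), none beyond the scatter. Compound 4 is estimated at 50000 nM, in a range from 20000 nM to 120000 nM, and is most likely to be reported only as a limit again.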

Compound 4, half-maximal inhibitory concentration: > 50000 nM
Compound 4: no number, only a limit; the forecaster's own chance of this, stated with the estimate: 70%; the middle value lies on the limit itself.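

Moving the hydroxy group did not bring the compound off the limit in this assay: compound 4 gives > 50000 nM, which is a limit of the assay and not a number. Measured against the unsubstituted phenyl ring of compound 1, the change is an at least 1.0-fold higher number from compound 1 to compound 4 (0.04 log units; that floor lies within the scatter), so 3-hydroxyphenyl on this nitrogen gives no more of a readable shift than 4-hydroxyphenyl did. The steps that link compound 4 to compound 2 and to compound 3 join limit to limit and cannot be read, which means that the place of the hydroxy group on this ring shows no measurable difference here, and the series now sits largely at one edge of the assay: the limit of > 50000 nM in this assay, at which 3 of the 4 values shown sit.

From the compounds shown here alone, only compound 1 carries an actual number so far, and it remains open whether an amine, a carboxylic acid or a methoxy group on this ring would give a value clear of the limit. Going by these compounds, it also remains open whether a change elsewhere on the shared core would bring compound 4 into the range where a step between the two hydroxyphenyl compounds could be read.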